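The compounds below may be only part of what the source reports. "The series", "measured", "known", "first", "only" and "open" are said of these compounds alone.

Measured compounds:
compound 1 `CNC(=O)N1CCCc2ccc(NC(=O)c3cccc(-c4ccccc4)c3)cc21` — 1.39%
compound 2 `CNC(=O)N1CCCc2ccc(NC(=O)c3ccc(-c4ccncc4)cc3)cc21` — 88.7%
compound 3 `CNC(=O)N1CCCc2ccc(NC(=O)c3cccc(-c4cc[nH]n4)c3)cc21` — 89.7%

In a functional assay on MV4-11 cells (Homo sapiens) for antiproliferative activity, with a stated time of 6 days, tested at 6.25 uM (on this read-out higher numbers stand for a stronger effect at the one concentration tested and lower numbers for a weaker effect), compound 2 gives 88.7%, the second highest of the three numbers. Compound 3 gives 89.7%, within the scatter of compound 2, so no order between the two can be read. Compound 1 gives 1.39%, far lower than compound 2 and beyond the scatter. Within the data shown here, the one step between compounds that differ in a single place is a number 88.3 percentage points higher from compound 1 to compound 3 (beyond the scatter), a phenyl giving way to a five-membered aromatic heterocycle.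

Compound 4 `CNC(=O)N1CCCc2ccc(NC(=O)c3ccc(-c4cnn(C(C)=O)c4)cc3)cc21` has not been measured. It differs from compound 2 by 1-acetyl-1H-pyrazol-4-yl in place of pyridin-4-yl on an aromatic carbon. The step from compound 1 to compound 3 bears on it in that a five-membered heterocycle with two ring nitrogens on the benzamide again takes the place of a six-membered aromatic ring, and both such groups measured so far sit at the high end. Among the measured compounds shown here, no measured compound carries an acetyl on the pyrazole nitrogen, so the effect of that group is untested. A step of a number 13.7 percentage points lower from compound 2 to compound 4 (beyond the scatter) is expected, most likely within the scatter, with some downward uncertainty. Compound 4 is estimated at 75%, range 40% to 95%.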

Compound 4, a percentage reported as inhibition, at one concentration (the size of the read-out at that concentration, not a potency): 83.8%
Compound 4: middle estimate off by 8.8 percentage points, on the low side; the range from low to high includes it.
By their numbers in this assay, from the lowest: compound 1; then compounds 4, 2 and 3 (each within the scatter of the next).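

In this assay the change at this place, on an aromatic carbon para to a large group, comes out as a number 4.9 percentage points lower from compound 2 to compound 4 (within the scatter), so no difference between the two groups can be read. Among these compounds, a six-membered aromatic ring with 1 hetero atom can therefore give way here to a five-membered aromatic ring with 2 hetero atoms that also carries an acetyl, and the high read-out is kept; the earlier compounds held no acetyl and no pair differing at this place. Nothing measured on these compounds speaks to why the read-out holds across this change.

On these data alone, what the acetyl itself contributes stays open: the plain 1H-pyrazol-4-yl, or a propanoyl on the same ring nitrogen, would separate it from the ring. A read-out at one concentration also leaves open any difference in potency between compound 2 and compound 4.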